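The source may report more compounds than this note shows. Statements on the series, on what has been measured and on what is new or still open speak of the compounds shown alone.

Measured in an ADME assay on MDCK cells (Canis lupus familiaris) for cytotoxicity; on this read-out lower numbers stand for higher toxicity in this test and higher numbers for lower toxicity in this test:
- Compound 1 `CC(=O)Nc1ccc2oc(-c3ccnc(C(=O)N4CC5(CCN(C(c6ccccc6)c6nnn(C)n6)CC5)C4)c3)nc2c1`: 32100 nM
- Compound 2 `CC(=O)Nc1ccc2oc(-c3ccnc(C(=O)N4CCN(C(c5cccc(F)c5)c5nnn(C)n5)CC4)c3)nc2c1`: > 50000 nM
- Compound 3 `CC(=O)Nc1ccc2oc(-c3ccnc(C(=O)N4CCN([C@H](c5ccc(F)cc5)c5nnn(C)n5)CC4)c3)nc2c1`: > 200000 nM

Compound 1 is the only one of the three with a plain number. Compound 2 stands at > 50000 nM, which is a limit of the assay and not a number. The entry for compound 3, > 200000 nM, is also a limit. Compound 4 `COc1ccc(C(c2nnn(C)n2)N2CCN(C(=O)c3cc(-c4nc5cc(NC(C)=O)ccc5o4)ccn3)CC2)cc1` has not yet been measured. It differs from compound 2 as follows: 4-methoxyphenyl in place of 3-fluorophenyl on a saturated chain carbon bound to an amine nitrogen in a ring and an aromatic carbon. In words, it has 4-methoxyphenyl in place of 3-fluorophenyl on a saturated chain carbon bound to an amine nitrogen in a ring and an aromatic carbon. Within the data shown here, no measured step bears on this change in this assay, so no step beyond the scatter is expected. The expected step is a step that the limit leaves unreadable from compound 2 to compound 4. For compound 4 the estimate is 60000 nM, with an expected range from 25000 nM to 200000 nM.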

Compound 4, half-maximal cytotoxic concentration: > 50000 nM
Compound 4 was reported as a limit; the forecaster's own chance of this, stated with the estimate: 65%; the middle value lies beyond the limit too.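

Compound 2 and compound 4 are both reported only as limits in this assay, and the step between them cannot be read. As far as these compounds go, how 4-methoxyphenyl in place of 3-fluorophenyl changes the result in this assay remains open.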